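Aryloxy variation on a coumarin-linked pyrazole series

The source may hold more compounds than are shown below. What is called first, only, known or untested is meant among the compounds shown, and "the series" means these compounds.

Measured compounds in a functional assay on HepG2 cells (Homo sapiens) for antiproliferative activity, read by MTT assay, with a stated time of 72 h; on this read-out higher numbers stand for weaker inhibition and lower numbers for stronger inhibition:
- compound 1 `Cc1nn(C)c(Oc2cccc(F)c2F)c1/C=N\CCCCCCOc1cc2oc(=O)cc(C)c2cc1Cl`: > 25000 nM
- compound 2 `Cc1nn(C)c(Oc2ccc(F)cc2F)c1/C=N\CCCCCCOc1cc2oc(=O)cc(C)c2cc1Cl`: > 25000 nM
- compound 3 `Cc1nn(C)c(Oc2cccc(Br)c2)c1/C=N\CCCCCCOc1cc2oc(=O)cc(C)c2cc1Cl`: 6830 nM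

Compound 1 stands at a limit of this assay, > 25000 nM, not at a number. Compound 2 likewise sits at a limit, so the step that the two limits leave unreadable from compound 1 to compound 2 cannot be read. Among the compounds with values here, compound 3 gives a number, and the step of an at least 3.6-fold lower number from compound 1 to compound 3 (0.56 log units; beyond the scatter) is the only readable step from compound 1; both ends of the readable evidence rest on (the limit of > 25000 nM in this assay, at which 2 of the 3 values shown sit).

Compound 4 `Cc1nn(C)c(Oc2ccc(OC(F)(F)F)cc2)c1/C=N\CCCCCCOc1cc2oc(=O)cc(C)c2cc1Cl` differs from compound 1 by 4-(trifluoromethoxy)phenyl in place of 2,3-difluorophenyl on an oxygen on an aromatic ring. Only compound 3 shows that a change at this position can move the read-out off the limit, so a number below the limit is possible but not assured. Compound 4 is estimated at 15000 nM (range 4000 nM to 50000 nM), an expected step of an at least 1.6-fold lower number from compound 1 to compound 4 (0.22 log units; that floor lies within the scatter).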

Compound 4, half-maximal inhibitory concentration: 8160 nM
The estimate for compound 4 lay 1.8-fold (0.26 log units) above the measured number; low and high end bracket the measured number.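

In this assay, 4-(trifluoromethoxy)phenyl is a second group at this position that leaves the limit, with an at least 3.0-fold lower number from compound 1 to compound 4 (0.48 log units; beyond the scatter) and an at least 3.0-fold lower number from compound 2 to compound 4 (0.48 log units; beyond the scatter); these are floors, not sizes, since one end of each step is a limit: the limit of > 25000 nM in this assay, at which 2 of the 4 values shown sit. Compound 3 no longer stands alone, and with a 1.2-fold higher number from compound 3 to compound 4 (0.08 log units; within the scatter) the two groups cannot be separated on this read-out. Across these four compounds, both difluorophenyl groups sit at the limit and both rings with a single substituent give numbers, with no compound against this.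

On these data alone, whether an unsubstituted phenyl or a 4-aminophenyl would follow this split stays open. As far as these compounds go, the true size of the steps from compound 1 and compound 2 also stays open.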